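The source may report more compounds than this note shows. Statements on the series, on what has been measured and on what is new or still open speak of the compounds shown alone.

Measured in a functional assay on cells for antagonist activity at prostaglandin E2 receptor EP1 subtype (Rattus norvegicus), read by fluorescence and calcium flux, with a stated time of 60 s; a higher number here means a weaker inhibitor, a lower number a stronger inhibitor:

compound 1 `O=C(O)c1cccc(Cc2c(-c3ccc(Cl)cc3)nn3cc(Cl)ccc23)n1` gives 1100 nM
compound 2 `O=C(O)c1cccc(Cc2c(-c3ccoc3)nn3cc(Cl)ccc23)n1` gives 130 nM
compound 3 `O=C(O)c1cccc(Cc2c(C3CC3)nn3cc(Cl)ccc23)n1` gives 1500 nM

Compound 3 carries the highest number of the three, but it lies within the scatter of compound 1 (a 1.4-fold higher number from compound 1 to compound 3 (0.13 log units; within the scatter)) and only stands clearly apart from compound 2 (a 12-fold higher number from compound 2 to compound 3 (1.06 log units; beyond the scatter)). Compound 4 `O=C(O)c1cccc(Cc2c(N3CCCCC3)nn3cc(Cl)ccc23)n1` follows from compound 3 by piperidin-1-yl in place of cyclopropyl on an aromatic carbon. Within the data shown here, none of the measured steps exchanges one non-aromatic group for another at this position, so the bearing is indirect: a 1.4-fold higher number from compound 1 to compound 3 (0.13 log units; within the scatter) stayed within the scatter, while an 8.5-fold lower number from compound 1 to compound 2 (0.93 log units; beyond the scatter) and a 12-fold higher number from compound 2 to compound 3 (1.06 log units; beyond the scatter) show that among the three groups tried only furan-3-yl pulled the number down substantially. Piperidin-1-yl is neither furan-3-yl nor an aromatic ring, and the two non-furan groups sit close together. A step of no more than the scatter is therefore expected in this assay, estimated as a 1.2-fold lower number from compound 3 to compound 4 (0.06 log units; within the scatter). Compound 4 is expected to give about 1300 nM, with a range from 350 nM to 5000 nM.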

Compound 4, half-maximal inhibitory concentration: 79 nM
The estimate for compound 4 lay 16-fold (1.22 log units) above the measured number; the whole stated range lies above it.
By their numbers in this assay, from the lowest: compounds 4 and 2 (each within the scatter of the next); then compounds 1 and 3 (each within the scatter of the next).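

In this assay, piperidin-1-yl gives a 19-fold lower number from compound 3 to compound 4 (1.28 log units; beyond the scatter) and also a 14-fold lower number from compound 1 to compound 4 (1.14 log units; beyond the scatter) and so joins furan-3-yl as a second group at this position that sits well apart from cyclopropyl and 4-chlorophenyl. With a 1.6-fold lower number from compound 2 to compound 4 (0.22 log units; within the scatter) and a non-aromatic ring on one side of that comparison, an aromatic ring at this position is not required for the low numbers, and ring aromaticity does not sort the series: 4-chlorophenyl goes against it on one side and cyclopropyl on the other. Nothing measured here accounts for the large step from cyclopropyl to piperidin-1-yl.

From the compounds shown here alone, whether the ring nitrogen of piperidin-1-yl or the six-membered ring itself matters remains open, and cyclohexyl would separate the two. Morpholin-4-yl and an open-chain amine such as diethylamino would test how much of the ring this position needs.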